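From Ethyl to Prop-1-en-1-yl: A Small Expected Step

The compounds below may be only part of what the source reports. "The series", "measured", "known", "first", "only" and "open" are said of these compounds alone.

In a functional assay on the whole organism with Mus musculus as the target (a lower number here means that less compound is needed, a higher number that more compound is needed for the effect), compound 1 `CC/C=C(\CC)C(=O)O` gives 1.6 umol/kg. Going by the values given here, the only other measured compound, compound 2 `CC/C=C(\CCCC)C(=O)O`, gives 0.87 umol/kg. These two values lie within the scatter of each other, so the numbers do not separate them. Compound 3 `C/C=C/C(=C\CC)C(=O)O` has not yet been measured. Its difference from compound 1 is this: prop-1-en-1-yl in place of ethyl on a double-bonded chain carbon bound to a carbonyl carbon and a double-bonded chain carbon. The new group sits on a double-bonded chain carbon bound to a carbonyl carbon and a double-bonded chain carbon. Among the compounds with values here, the only measured guide is a 1.8-fold lower number from compound 1 to compound 2 (0.26 log units; within the scatter), which puts ethyl in place of hydrogen on a saturated chain carbon. That is a different change, and it stayed within the scatter. Within the data shown here, no measured step touches the place altered here, so the guidance is weak. The expected step in this assay is a 1.1-fold lower number from compound 1 to compound 3 (0.06 log units; within the scatter), and nothing beyond the scatter is expected. Compound 3 is estimated at 1.4 umol/kg, with an expected range from 0.5 umol/kg to 4 umol/kg.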

Compound 3, dose for half-maximal effect in the Mus musculus assay: 1.4 umol/kg
Compound 3: middle estimate and measured number agree at the digits printed, within the range that was stated.
By their numbers in the Mus musculus assay, from the lowest: compounds 2, 3 and 1 (each within the scatter of the next).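

Going by these compounds alone, at the double-bonded chain carbon bound to a carbonyl carbon and a double-bonded chain carbon, the earlier compounds offered no measured step, and now there is one: in the Mus musculus assay compound 1 gives 1.6 umol/kg and compound 3 gives 1.4 umol/kg, and prop-1-en-1-yl in place of ethyl gives a 1.1-fold lower number from compound 1 to compound 3 (0.06 log units; within the scatter), so the two compounds are not separated by this read-out. In a physicochemical assay for lipophilicity (a lower number here means a more polar compound, a higher number a more lipophilic compound), compound 1 gives 2.06 and compound 3 gives 2.22, and the same swap gives a number 0.16 log units higher from compound 1 to compound 3 (within the scatter), so neither read-out separates the two groups at this position. No measurement at hand offers a reason for these results.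

As far as these compounds go, only ethyl and prop-1-en-1-yl are seen at this position, so how a phenyl ring or an amine there would read in the Mus musculus assay stays open. Also open, from the compounds shown here alone, is whether the carboxylic acid of the shared core could give way to an amide.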